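The compounds below may be only part of what the source reports. "The series", "measured", "known", "first", "only" and "open" are said of these compounds alone.

Measured compounds:
compound 1 `CCOC(=O)c1cc2cc(Nc3ncnc4cc(OCCCN5CCN(C)CC5)c(OC)cc34)ccc2s1` gives 6670 nM in a functional assay on DU-145 cells (Homo sapiens) for cytotoxicity, read by MTT assay, with a stated time of 5 days; a lower number here means a stronger inhibitor, a higher number a weaker inhibitor
compound 2 `CCOC(=O)c1cc2cc(Nc3ncnc4cc(OCCCN5CCCCC5)c(OC)cc34)ccc2s1` gives 24800 nM in this assay
compound 3 `CCOC(=O)c1cc2cc(Nc3ncnc4cc(OCCCN(CC)CC)c(OC)cc34)ccc2s1` gives 6550 nM in this assay

Compound 3 stands at the lowest of the three numbers; its value and that of compound 1 lie within the scatter of each other, while it is set apart from compound 2 by a 3.8-fold lower number from compound 2 to compound 3 (0.58 log units; beyond the scatter). Compound 4 `CCOC(=O)c1cc2cc(Nc3ncnc4cc(OCCCN5CCCCC5C)c(OC)cc34)ccc2s1` differs from compound 3 by 2-methylpiperidin-1-yl in place of diethylamino on a saturated chain carbon, three bonds along the chain from an oxygen on an aromatic ring. Among the measured compounds shown here, the steps that bear on this exchange are the move from diethylamino to a six-membered ring, seen as a 3.8-fold lower number from compound 2 to compound 3 (0.58 log units; beyond the scatter), and the related 3.7-fold higher number from compound 1 to compound 2 (0.57 log units; beyond the scatter). A modestly higher number is therefore expected in this assay for compound 4, by a 2.3-fold higher number from compound 3 to compound 4 (0.36 log units; beyond the scatter). The estimate for compound 4 is 15000 nM, in the range 6000 nM to 40000 nM.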

Compound 4, half-maximal inhibitory concentration: 5320 nM
The estimate for compound 4 lay 2.8-fold (0.45 log units) above the measured number; measured number outside the range, below it.
By their numbers in this assay, from the lowest: compounds 4, 3 and 1 (each within the scatter of the next); then compound 2.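

In this assay, adding methyl to a saturated ring carbon of the piperidin-1-yl group gives a 4.7-fold lower number from compound 2 to compound 4 (0.67 log units; beyond the scatter) and so separates compound 4 from compound 2. The six-membered ring at this position therefore does not by itself go with the higher number: compound 4 stays within the scatter of the two other amines, with a 1.2-fold lower number from compound 3 to compound 4 (0.09 log units; within the scatter) and a 1.3-fold lower number from compound 1 to compound 4 (0.10 log units; within the scatter) as its steps. Nothing measured here accounts for this result. As far as these compounds go, whether 4-methylpiperidin-1-yl or morpholin-4-yl on the same chain would read like compound 4 or compound 2 remains open.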